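This account rests on a few compounds, and the source may have more. Where it says the series, first, only, none or still open, it means among the compounds named here.

In an ADME assay on DU-145 cells (Homo sapiens) for cytotoxicity, read by MTT assay, with a stated time of 72 h (a lower number here means a stronger inhibitor, a higher number a weaker inhibitor), compound 3 `COc1ccc(C2=C(c3cc(OC)c(OC)c(OC)c3)C(=O)C(O)C2)cc1Cl` gives 40 ug/mL, a higher number than compound 2 `COc1ccc(C2=C(c3cc(OC)c(OC)c(OC)c3)C(=O)C(OC(C)=O)C2)cc1F` at 16 ug/mL. Compound 1 `COc1ccc(C2=C(c3cc(OC)c(OC)c(OC)c3)C(=O)C(OC(C)=O)C2)cc1OC(C)C` gives > 100 ug/mL, which is a limit of the assay and not a number. Compound 4 `COc1ccc(C2=C(c3cc(OC)c(OC)c(OC)c3)C(=O)C(OC(C)=O)C2)cc1Cl` differs from compound 3 in one place acetyl in place of hydrogen on an oxygen on a saturated carbon, so hydroxy becomes acetoxy. Among the measured compounds shown here, the one measured step, an at least 6.2-fold lower number from compound 1 to compound 2 (0.79 log units; beyond the scatter), concerns an aromatic carbon and keeps the acetoxy, so it bears on this change only loosely. For the measured compounds named here, no measured step makes this change itself. Compound 2, which carries acetoxy, sits at 16 ug/mL, so a modest move toward a lower number in this assay is expected. The expected step is a 1.8-fold lower number from compound 3 to compound 4 (0.26 log units; within the scatter). For compound 4, the estimate is 22 ug/mL, with an expected range of 8 ug/mL to 60 ug/mL.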

Compound 4, half-maximal inhibitory concentration: 64 ug/mL
Compound 4: middle estimate off by 2.9-fold (0.46 log units), on the low side; the measured number lies above the stated range.
By their numbers in this assay, from the lowest: compound 2; then compounds 3 and 4 (each within the scatter of the next). At a limit, above all of these: compound 1.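

In this assay, acetyl in place of hydrogen on an oxygen on a saturated carbon, so hydroxy to acetoxy, gives a 1.6-fold higher number from compound 3 to compound 4 (0.20 log units; within the scatter), with chloro on the aromatic carbon in both compounds, and this step lies within the scatter. With acetoxy kept, the aromatic carbon shows a clearer effect, as chloro in place of fluoro gives a 4.0-fold higher number from compound 2 to compound 4 (0.60 log units; beyond the scatter) and so shifts the number more than the acetyl does. Compound 1 gives > 100 ug/mL, which is a limit of the assay and not a number. Chloro in place of isopropoxy on the aromatic carbon gives an at least 1.5-fold lower number from compound 1 to compound 4 (0.19 log units; that floor lies within the scatter), so this step is only a floor.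

On these data alone, whether hydroxy and acetoxy also match when fluoro sits on the aromatic carbon remains open. So does the effect of a benzoyl group or a methyl ether on this oxygen.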